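The source may report more compounds than this note shows. Statements on the series, on what has been measured and on what is new or still open speak of the compounds shown alone.

The measured compounds:
Compound 1, `CCCc1nc(-c2ccccc2)c(CNCCN2CCN(c3cccc(C)c3C)CC2)o1`, which in an assay on HEK293 cells for inhibition of Voltage-dependent T-type calcium channel subunit alpha-1G (Homo sapiens), read by patch clamp (a higher number here means a weaker inhibitor, a lower number a stronger inhibitor), gives 1710 nM.
Compound 2, `CCCc1nc(-c2ccccc2)c(CNCCN2CCN(c3ccccc3)CC2)o1`, which in this assay gives 10300 nM.
Compound 3, `CCCc1nc(-c2ccccc2)c(CNCCN2CCN(c3cccc(Cl)c3)CC2)o1`, which in this assay gives 1450 nM.

Compound 3 sits alongside compound 1 at the low end of these three numbers, the two separated only by a 1.2-fold lower number from compound 1 to compound 3 (0.07 log units; within the scatter), which is within the scatter, while compound 2 lies well apart, as a 7.1-fold lower number from compound 2 to compound 3 (0.85 log units; beyond the scatter) shows. Compound 4, `CCCc1nc(-c2ccccc2)c(CNCCN2CCN(c3ccccc3C(F)(F)F)CC2)o1`, differs from compound 3 in one place: 2-(trifluoromethyl)phenyl in place of 3-chlorophenyl on an amine nitrogen in a ring. Going by the values given here, two measured steps bear on this change. The unsubstituted phenyl of compound 2 gave the highest number, and a 6.0-fold higher number from compound 1 to compound 2 (0.78 log units; beyond the scatter) together with a 7.1-fold lower number from compound 2 to compound 3 (0.85 log units; beyond the scatter) shows that carrying a substituent on the aryl ring lowered the number by a modest amount in both cases. Among the compounds with values here, no measured compound carries a trifluoromethyl group, and none tests this pattern of substitution, so the size of the step cannot be read directly. Because compound 3 gives 1450 nM with a substituted aryl ring and compound 4 keeps one, compound 4 is expected to stay near it, with the step of a 1.2-fold higher number from compound 3 to compound 4 (0.09 log units; within the scatter) expected to lie within or only slightly beyond the scatter. Compound 4 is therefore estimated at 1800 nM in this assay, with a range from 700 nM to 5000 nM.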

Compound 4, half-maximal inhibitory concentration: 2100 nM
The estimate for compound 4 lay 1.2-fold (0.07 log units) below the measured number, and the stated range covers the measured number.
By their numbers in this assay, from the lowest: compounds 3, 1 and 4 (each within the scatter of the next); then compound 2.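

With a 4.9-fold lower number from compound 2 to compound 4 (0.69 log units; beyond the scatter), 2-(trifluoromethyl)phenyl in this assay extends to a third group what 2,3-dimethylphenyl and 3-chlorophenyl had shown: among the compounds shown, each substituted aryl group on the amine nitrogen in the ring gives a lower number than plain phenyl, and no compound here goes against this. The comparisons among the substituted compounds, a 1.4-fold higher number from compound 3 to compound 4 (0.16 log units; within the scatter) and a 1.2-fold higher number from compound 1 to compound 4 (0.09 log units; within the scatter), both stay within the scatter, so this assay does not separate 2-(trifluoromethyl)phenyl from either 3-chlorophenyl or 2,3-dimethylphenyl, although the entering group has more heavy atoms than 3-chlorophenyl and carries fluorine in place of chlorine. The data given offer no independent measurement that would explain these numbers.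

The compounds shown leave open whether moving one and the same group to another place on the aryl ring would change the number beyond the scatter. They also leave open whether a methoxy group or a carboxylic acid on that ring would give a number close to those of compounds 1, 3 and 4, or one closer to that of compound 2.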